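The source may report more compounds than this note shows. Statements on the series, on what has been measured and on what is new or still open speak of the compounds shown alone.

Three compounds share one core and are compared in an assay for inhibition of Type-2 angiotensin II receptor (Rattus norvegicus); a lower number here means a stronger inhibitor, a higher number a weaker inhibitor. Compound 1, `CCCCCN(CCCCC)C(=O)N1CCN(C(=O)N(c2ccccc2)c2ccccc2)[C@@H](C(=O)O)C1`, gives 4.5 nM. Compound 2, `CCCCCN(CCCCC)C(=O)N1CCN(C(=O)N(c2ccccc2)c2ccccc2)[C@H](C(=O)O)C1`, gives 1.4 nM, and the step of a 3.2-fold lower number from compound 1 to compound 2 (0.51 log units; beyond the scatter) is explained only by the fact that compounds 1 and 2 differ only in the configuration as drawn. Compound 3, `CCCCCN(C)C(=O)N1CCN(C(=O)N(c2ccccc2)c2ccccc2)[C@H](C(=O)O)C1`, gives 15 nM, the weakest of the three, with the large step of an 11-fold higher number from compound 2 to compound 3 (1.03 log units; beyond the scatter) showing how much the pentyl chain mattered. Compound 4, `CN(C(=O)N1CCN(C(=O)N(c2ccccc2)c2ccccc2)[C@H](C(=O)O)C1)c1ccccc1`, carries the change (phenyl in place of pentyl on an amide-type nitrogen). For the measured compounds named here, no measured step swaps chain for ring, so the direction is uncertain; the step of an 11-fold higher number from compound 2 to compound 3 (1.03 log units; beyond the scatter) suggests that losing the chain costs potency, and the estimated step is a 2.7-fold higher number from compound 3 to compound 4 (0.43 log units; beyond the scatter). Compound 4 is expected to give about 40 nM, within 8 nM to 200 nM.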

Compound 4, half-maximal inhibitory concentration: 170 nM
Estimate against measurement, compound 4: 4.3-fold (0.63 log units) below, and the stated range covers the measured number.
By their numbers in this assay, from the lowest: compound 2; then compound 1; then compound 3; then compound 4.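

In this assay, putting phenyl in place of pentyl on this amide-type nitrogen gives an 11-fold higher number from compound 3 to compound 4 (1.05 log units; beyond the scatter) and so shows that an aromatic ring does not stand in for the chain here. The whole change from dipentylamino to methyl(phenyl)amino adds up to a 120-fold higher number from compound 2 to compound 4 (2.08 log units; beyond the scatter) and shows that the potency of compound 2 is lost in full once both pentyl chains are gone. Going by these compounds, whether a benzyl or cyclohexyl group in the same place would keep more potency stays open, as does whether phenyl would cost as much with the second pentyl chain kept in place of methyl. Nothing measured here bears on why phenyl costs so much.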